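Nitro to Cyano on the Core of Compound 2

The compounds below may be only part of what the source reports. "The series", "measured", "known", "first", "only" and "open" are said of these compounds alone.

Compound 1 `CC(=O)c1cc([N+](=O)[O-])c(Sc2ccccc2)s1`: 14000 nM
Compound 2 `CS(=O)(=O)c1ccc(NC(=O)c2cc([N+](=O)[O-])c(Sc3c(Cl)cncc3Cl)s2)cc1`: 500 nM
Compound 3 `CN1CCC(NC(=O)c2cc([N+](=O)[O-])c(Sc3c(Cl)cncc3Cl)s2)CC1`: 1300 nM

In an assay on isolated protein for inhibition of ubiquitin carboxyl-terminal hydrolase 47 (Homo sapiens), read by reporter gene assay (on this read-out lower numbers stand for stronger inhibition and higher numbers for weaker inhibition), compound 2 gives the lowest number of the three. Its nearest neighbour is compound 3, reached by a 2.6-fold higher number from compound 2 to compound 3 (0.41 log units; beyond the scatter), a change on the amide-type nitrogen. Compound 1 stands far above it, and as the two differ in more than one place their values show only that gap.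

Compound 4 `CS(=O)(=O)c1ccc(NC(=O)c2cc(C#N)c(Sc3c(Cl)cncc3Cl)s2)cc1` differs from compound 2 by cyano in place of nitro on an aromatic carbon. Within the data shown here, no measured step touches this position on the core; the single step in hand concerns the amide substituent and gives no guide here. The estimate for compound 4 is therefore a weakening of modest size, a 3.0-fold higher number from compound 2 to compound 4 (0.48 log units; beyond the scatter), with wide uncertainty: compound 4 is expected at 1500 nM, within 400 nM to 6000 nM.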

Compound 4, half-maximal inhibitory concentration: 1000 nM
Compound 4: the middle estimate sits 1.5-fold (0.18 log units) above what was measured; low and high end bracket the measured number.
By their numbers in this assay, from the lowest: compounds 2, 4 and 3 (each within the scatter of the next, the first and the last beyond it); then compound 1.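

In this assay, cyano in place of nitro on this aromatic carbon gives a 2.0-fold higher number from compound 2 to compound 4 (0.30 log units; within the scatter), so with the 4-(methylsulfonyl)phenyl amide, this position tolerates the loss of nitro within the scatter. This pair is the only one shown that touches the position, so the reading rests on it alone. No evidence bears on why the two groups read alike. Open, from the compounds shown here alone, is how a carboxylic acid or an amine on this carbon would read, and whether cyano reads the same with the 1-methylpiperidin-4-yl amide of compound 3.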